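The source may report more compounds than this note shows. Statements on the series, on what has been measured and on what is new or still open speak of the compounds shown alone.

Of the compounds shown here, three have been measured so far. Compound 1 `O=C(OC1CCCCC1)N1CCC(c2nc(-c3ccc4ccccc4n3)no2)CC1` gives 580 nM in a functional assay on Shh Light II cells (Mus musculus) for inhibition, read by a luciferase reporter; a higher number here means a weaker inhibitor, a lower number a stronger inhibitor. Compound 3 `C[C@H]1C[C@H](c2nc(-c3ccc4ccccc4n3)no2)CCN1C(=O)Nc1ccccc1Cl` gives 900 nM, a value within the scatter of that of compound 1. Compound 2 `Cn1c(-c2noc(N3CCN(C(=O)NC4CCCCC4)CC3)n2)nc2ccccc21`, built on a different core, gives 5 nM, far stronger than compound 1. So compound 1 stands second highest of the three numbers, close to compound 3 and well apart from compound 2.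

Compound 4 `Cc1noc(C)c1NC(=O)N1CCC(c2nc(-c3ccc4ccccc4n3)no2)CC1` is not yet measured. It differs from compound 1 in one place: (3,5-dimethyl-1,2-oxazol-4-yl)amino in place of cyclohexyloxy on a carbonyl carbon. Among the compounds with values here, no measured pair shows this change, so the expectation rests on the neighbouring values alone. Compound 4 is expected to sit near compound 1, with a step of a 1.5-fold lower number from compound 1 to compound 4 (0.16 log units; within the scatter) in this assay. The estimate for compound 4 is 400 nM, in the range 100 nM to 1500 nM.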

Compound 4, half-maximal inhibitory concentration: 3000 nM
Compound 4: middle estimate off by 7.5-fold (0.88 log units), on the low side; the whole stated range lies below it.
By their numbers in this assay, from the lowest: compound 2; then compounds 1 and 3 (each within the scatter of the next); then compound 4.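

In this assay, putting (3,5-dimethyl-1,2-oxazol-4-yl)amino in place of cyclohexyloxy on a carbonyl carbon gives a 5.2-fold higher number from compound 1 to compound 4 (0.71 log units; beyond the scatter), so the inhibitor becomes weaker. Within the data shown here, this is the first one-place comparison, and it shows that the group on this carbonyl alone can shift the value beyond the scatter while the rest of the molecule stays fixed. Nothing measured here explains the loss.

As far as these compounds go, the change replaces both the ring and the atom linking it to the carbonyl, so which of these matters remains open. A (3,5-dimethyl-1,2-oxazol-4-yl)oxy group on the same carbonyl would separate the two.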